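The source may report more compounds than this note shows. Statements on the series, on what has been measured and on what is new or still open speak of the compounds shown alone.

Measured compounds:
Compound 1, `Oc1ccccc1CNc1ccc(N2CCCCC2)cc1`: "not active" (no number reported) in a functional assay on Jurkat cells (Homo sapiens) for activation, with a stated time of 24 h; a lower number here means that less compound is needed, a higher number that more compound is needed for the effect.
Compound 2, `Oc1ccccc1CNc1ccc(-c2ccccc2F)cc1`: 2150 nM in this assay.

For the measured compounds named here, compound 2 holds the only single number in this assay; compound 1 gives no number there. Compound 3, `Oc1ccccc1CNc1ccc(-c2ccccc2Cl)cc1`, differs from compound 2 by chloro in place of fluoro on an aromatic carbon. Going by the values given here, no measured pair shows a change of this kind, so the step from compound 2 to compound 3 is expected to be small, perhaps modestly toward a lower value, and quite possibly none beyond the scatter: a 1.4-fold lower number from compound 2 to compound 3 (0.16 log units; within the scatter). Compound 3 is accordingly estimated at 1500 nM, with a range from 500 nM to 5000 nM.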

Compound 3, half-maximal effective concentration: "not active" (no number reported)
The entry for compound 3 holds no number, so the estimate cannot be set against anything.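

For the compounds shown here, with compound 3 reported as "not active" (no number reported) in this assay, no step from compound 2 can be read. The compounds shown leave open how 2-chlorophenyl compares numerically with 2-fluorophenyl. No available evidence bears on this result.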